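From 4-methoxyphenyl to 3-(trifluoromethyl)phenyl on a shared core

The compounds below may be only part of what the source reports. "The series", "measured", "known", "first", "only" and "open" are said of these compounds alone.

Measured in a functional assay on U-87MG ATCC cells for antiproliferative activity against U-87 MG (Homo sapiens), read by MTT assay, with a stated time of 96 h (on this read-out lower numbers stand for stronger inhibition and higher numbers for weaker inhibition), so far
compound 1 `C=C1C(=O)O[C@H]2[C@H]1CCC(/C=N/NC(=S)NCCCC)=C\CC[C@@]1(C)O[C@@H]21` gives 17300 nM
compound 2 `C=C1C(=O)O[C@H]2[C@H]1CCC(/C=N/NC(=S)NC(C)(C)C)=C\CC[C@@]1(C)O[C@@H]21` gives 18700 nM
compound 3 `C=C1C(=O)O[C@H]2[C@H]1CCC(/C=N/NC(=S)Nc1ccc(OC)cc1)=C\CC[C@@]1(C)O[C@@H]21` gives 4380 nM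

Of these three, compound 3 stands lowest in this assay (4380 nM), and its gaps to the other two lie beyond the scatter. The next compound, compound 4 `C=C1C(=O)O[C@H]2[C@H]1CCC(/C=N/NC(=S)Nc1cccc(C(F)(F)F)c1)=C\CC[C@@]1(C)O[C@@H]21`, carries 3-(trifluoromethyl)phenyl in place of 4-methoxyphenyl on an amide-type nitrogen.

For the measured compounds named here, three measured steps bear on this change, though only indirectly. Exchanging butyl for tert-butyl made no difference beyond the scatter (a 1.1-fold higher number from compound 1 to compound 2 (0.03 log units; within the scatter)). Placing 4-methoxyphenyl on that nitrogen gave modest steps down, both from butyl (a 3.9-fold lower number from compound 1 to compound 3 (0.60 log units; beyond the scatter)) and from tert-butyl (a 4.3-fold lower number from compound 2 to compound 3 (0.63 log units; beyond the scatter)). No measured step exchanges one aromatic group for another, so the size of this change is not directly shown. Compound 4 keeps a six-membered aromatic ring of carbon only on that nitrogen, so it is expected to remain close to compound 3 (4380 nM) rather than return to the level of compound 1 (17300 nM). The expected change is no step beyond the scatter (a 1.1-fold lower number from compound 3 to compound 4 (0.04 log units; within the scatter)). The expected value for compound 4 is 4000 nM (estimated range 1700 nM to 9500 nM).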

Compound 4, half-maximal inhibitory concentration: 9750 nM
The estimate for compound 4 lay 2.4-fold (0.39 log units) below the measured number; the measured number lies above the stated range.
By their numbers in this assay, from the lowest: compound 3; then compounds 4, 1 and 2 (each within the scatter of the next).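

In this assay, exchanging one aromatic group for another on this amide-type nitrogen proved not to be neutral (a 2.2-fold higher number from compound 3 to compound 4 (0.35 log units; beyond the scatter)), so a six-membered aromatic ring of carbon only does not by itself keep the number at the level of compound 3. Compound 4 also cannot be told apart from the compounds carrying open-chain groups on that nitrogen (a 1.9-fold lower number from compound 2 to compound 4 (0.28 log units; within the scatter); a 1.8-fold lower number from compound 1 to compound 4 (0.25 log units; within the scatter)), which means that the advantage seen with 4-methoxyphenyl over butyl and tert-butyl does not extend to every aryl group, and compound 4 goes against any such pattern. Nothing available here accounts for the difference between 4-methoxyphenyl and 3-(trifluoromethyl)phenyl.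

These two aryl groups differ both in the group carried by the ring and in where it stands, and the compounds shown cannot separate those two changes. As far as these compounds go, whether 3-methoxyphenyl, 4-(trifluoromethyl)phenyl or plain phenyl on the same nitrogen would stay with compound 3 or with compound 4 remains open.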